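The source may report more compounds than this note shows. Statements on the series, on what has been measured and on what is new or still open speak of the compounds shown alone.

In a functional assay on Huh-7 cells (Homo sapiens) for inhibition, read by CCK-8 assay, with a stated time of 72 h (on this read-out lower numbers stand for stronger inhibition and higher numbers for weaker inhibition), compound 1 (`O=C(/C=C/c1cccnc1)NCCCCCc1cccc(S(=O)(=O)Nc2ccccc2)c1`) gives 41.1 nM and compound 2 (`Cc1ccccc1NS(=O)(=O)c1cccc(CCCCCCNC(=O)/C=C/c2cccnc2)c1`) gives 0.525 nM as the lower of the two numbers, a gap beyond the usual scatter. Compound 3 (`CC(C)(C)c1ccc(NS(=O)(=O)c2cccc(CCCCCCNC(=O)/C=C/c3cccnc3)c2)cc1`) matches compound 2 except for one group: it carries 4-(tert-butyl)phenyl in place of 2-methylphenyl on a sulfonamide nitrogen. For the measured compounds named here, no measured pair shows what a swap at this place does on its own, so any expectation here is loose. Compound 2 already sits very low at 0.525 nM and from there a rise seems likelier than a further drop. A moderate rise beyond the scatter, meaning weaker inhibition, is therefore expected, and the estimated step of a 7.6-fold higher number from compound 2 to compound 3 (0.88 log units; beyond the scatter) gives its size. The estimated value for compound 3 is 4 nM (expected range 0.6 nM to 30 nM).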

Compound 3, half-maximal inhibitory concentration: 163 nM
Compound 3: the middle estimate sits 41-fold (1.61 log units) below what was measured; the whole stated range lies below it.
By their numbers in this assay, from the lowest: compound 2; then compound 1; then compound 3.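

In this assay, the group on the sulfonamide nitrogen proves to matter greatly: 4-(tert-butyl)phenyl in place of 2-methylphenyl gives a 310-fold higher number from compound 2 to compound 3 (2.49 log units; beyond the scatter) and so a large loss of inhibition. The earlier compounds shown here could not show this, since compound 1 and compound 2 differ in more than one place and no step between them can be read. Nothing available explains why this change costs so much.

The change alters both the alkyl group, methyl against tert-butyl, and its numbered ring position, so the compounds shown cannot separate these two differences. Open too, from the compounds shown here alone, is where 4-methylphenyl or 2-(tert-butyl)phenyl on this nitrogen would fall relative to compound 2 and compound 3, as each would change only one of the two.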